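This account rests on a few compounds, and the source may have more. Where it says the series, first, only, none or still open, it means among the compounds named here.

The measured compounds:

Compound 1, `O=C(CSc1nc(Nc2ccccc2)c2ccccc2n1)Nc1ccccc1Cl`: 24400 nM
Compound 2, `O=C(CSc1nc(Nc2ccccc2)c2ccccc2n1)Nc1ccc([N+](=O)[O-])cc1`: 16800 nM
Compound 3, `O=C(CSc1nc(Nc2ccccc2)c2ccccc2n1)Nc1ccc(C(F)(F)F)cc1`: 11100 nM

In a functional assay on MDA-MB-231 cells (Homo sapiens) for inhibition, read by MTT assay, with a stated time of 72 h (a lower number here means a stronger inhibitor, a higher number a weaker inhibitor), compound 1 gives the highest of the three numbers. Its nearest neighbour is compound 2, with a 1.5-fold lower number from compound 1 to compound 2 (0.16 log units; within the scatter); the furthest is compound 3, with a 2.2-fold lower number from compound 1 to compound 3 (0.34 log units; beyond the scatter), a modest step. Between the other two there is a 1.5-fold lower number from compound 2 to compound 3 (0.18 log units; within the scatter).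

Compound 4, `O=C(CSc1nc(Nc2ccccc2)c2ccccc2n1)Nc1ccc(Cl)cc1Cl`, keeps the shared core of compound 1 and changes only the amide-bound aryl group: chloro in place of hydrogen on an aromatic carbon, so that the 2-chlorophenyl becomes a 2,4-dichlorophenyl. For the measured compounds named here, no measured step adds a chloro to a ring that already carries one. Going by the values given here, the steps that bear on it are those that alter the same aryl group: exchanging the 2-chlorophenyl for a substituted phenyl lowered the number by little in the move to compound 2 and modestly in the move to compound 3, and exchanging one ring substituent for another did nothing beyond the scatter. Every change at this position has therefore left the number close to where it stood, with a slight tilt downward.

For compound 4 a step of a 1.4-fold lower number from compound 1 to compound 4 (0.16 log units; within the scatter) is expected, a small lowering that may well fall within the scatter. The estimate is 17000 nM, with a range from 8000 nM to 36000 nM.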

Compound 4, half-maximal inhibitory concentration: 19400 nM
The estimate for compound 4 lay 1.1-fold (0.06 log units) below the measured number, within the range that was stated.
By their numbers in this assay, from the lowest: compounds 3, 2, 4 and 1 (each within the scatter of the next, the first and the last beyond it).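

Adding a chloro to a ring that already carries one, para to a large group and meta to a chloro group, gives in this assay a 1.3-fold lower number from compound 1 to compound 4 (0.10 log units; within the scatter), so this second chloro leaves the number within the scatter of its starting point. For the compounds shown here, the 2,4-dichlorophenyl group also stands close to the two para-substituted aryl groups, with a 1.7-fold higher number from compound 3 to compound 4 (0.24 log units; within the scatter) and a 1.2-fold higher number from compound 2 to compound 4 (0.06 log units; within the scatter), and so adds no new separation: the only pair of the four compounds beyond the scatter remains compound 1 and compound 3. Nothing given here accounts for how little this position has responded to the change.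

The compounds shown leave open whether a group of another kind on this aryl ring, such as an amine, a carboxylic acid or a longer chain, would move the number beyond the scatter, since only chloro, nitro and trifluoromethyl appear there. They also leave open whether the phenylamino group on the shared core, which stays the same throughout, would respond more strongly to a change than the amide-bound aryl group has.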